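This account rests on a few compounds, and the source may have more. Where it says the series, first, only, none or still open, it means among the compounds named here.

Measured so far in a functional assay on ECa-109 cells (Homo sapiens) for antiproliferative activity, read by MTT assay, with a stated time of 48 h; on this read-out lower numbers stand for stronger inhibition and higher numbers for weaker inhibition:
- compound 1 `Cn1cc(C2=C(c3nn(CCCN4CCCCC4)c4ncccc34)C(=O)N(c3ccc(Cl)cc3)C2=O)c2ccccc21` gives > 100000 nM as a limit, not a number
- compound 2 `Cn1cc(C2=C(c3n[nH]c4ncccc34)C(=O)NC2=O)c2ccccc21` gives 46100 nM as a number

Among the measured compounds shown here, compound 2 at 46100 nM holds the only true number, so it cannot yet be ranked against another measured value. Compound 3 `Cn1cc(C2=C(c3nn(CCCN4CCCCC4)c4ncccc34)C(=O)NC2=O)c2ccccc21` carries 3-(piperidin-1-yl)propyl in place of hydrogen on an aromatic nitrogen and is otherwise the same as compound 2. For the measured compounds named here, no measured step isolates this change. Compound 1 carries the same group, but its imide nitrogen is also substituted, and its > 100000 nM is only a limit. A modest shift towards stronger inhibition is expected, with wide uncertainty and a real chance of no number at all. The expected change a 2.3-fold lower number from compound 2 to compound 3 (0.36 log units; beyond the scatter) is an estimate only. Compound 3 is expected at 20000 nM in this assay, with an estimated range of 3000 nM to 90000 nM.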

Compound 3, half-maximal inhibitory concentration: 42300 nM
Compound 3: middle estimate off by 2.1-fold (0.33 log units), on the low side; the range from low to high includes it.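

In this assay, 3-(piperidin-1-yl)propyl in place of hydrogen on an aromatic nitrogen gives a 1.1-fold lower number from compound 2 to compound 3 (0.04 log units; within the scatter), so this nitrogen carries the chain with no shift beyond the scatter. Hydrogen in place of 4-chlorophenyl on an amide-type nitrogen in a ring gives an at least 2.3-fold lower number from compound 1 to compound 3 (0.37 log units; beyond the scatter), which is the first reading of a change at that nitrogen with the chain held constant. Compound 1 stands at a limit, not a number, so this step is only a minimum: the limit of > 100000 nM in this assay, at which 1 of the 3 values shown sits.

On these data alone, whether a morpholine or a dimethylamine at the end of the chain, or a shorter ethyl linker, would give a number apart from these remains open. So does the size of the step at the amide-type nitrogen, and whether a small methyl group there behaves like 4-chlorophenyl.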